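This account rests on a few compounds, and the source may have more. Where it says the series, first, only, none or still open, it means among the compounds named here.

In a functional assay on HT-29 cells (Homo sapiens) for inhibition (on this read-out higher numbers stand for weaker inhibition and lower numbers for stronger inhibition), compound 1 `COc1cc(/C=C\c2ccc(N(C)C)c([N+](=O)[O-])c2)cc(OC)c1OC` gives > 5000 nM, which is a limit of the assay and not a number. For the measured compounds named here, compound 2 `COc1cc(/C=C/c2ccc(N(C)C)c(N)c2)cc(OC)c1OC` gives 300 nM, the only actual number so far on this read-out. Compound 3 `COc1cc(/C=C\c2ccc(N(C)C)c(N)c2)cc(OC)c1OC` has the same atoms and bonds as compound 2: the two compounds have the same atoms and bonds and differ only in configuration as drawn: 1 of 1 stereo elements differ; a double bond is drawn E in compound 2 and Z in compound 3. A double bond is drawn E in compound 2 and Z in compound 3. Going by the values given here, no measured pair shows this change on its own, so the judgement is uncertain, but a step towards stronger inhibition beyond the usual scatter is expected, a 10-fold lower number from compound 2 to compound 3 (1.00 log units; beyond the scatter). The estimated value for compound 3 is 30 nM, within an expected range of 4 nM to 300 nM.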

Compound 3, half-maximal inhibitory concentration: 4 nM
Compound 3: middle estimate off by 7.5-fold (0.88 log units), on the high side; measured number inside the range.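

In this assay, the configuration of the double bond alone carries a large effect, with a 75-fold lower number from compound 2 to compound 3 (1.88 log units; beyond the scatter); this step can be put on the double bond because nothing else separates the pair: the fact that compounds 2 and 3 differ only in the configuration as drawn. Compound 1 gives > 5000 nM, which is a limit of the assay and not a number. With the double bond drawn Z in both, amino in place of nitro on an aromatic carbon brings an at least 1200-fold lower number from compound 1 to compound 3 (3.09 log units; beyond the scatter), a step whose size rests on that limit: the limit of > 5000 nM in this assay, at which 1 of the 3 values shown sits.

The compounds shown leave open whether a hydroxyl or an acetamide could stand in place of the amino group and keep this level of inhibition.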